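The compounds below may be only part of what the source reports. "The series", "measured", "known", "first", "only" and "open" are said of these compounds alone.

Measured compounds, in a functional assay on Huh7.5.1 cells (Homo sapiens) for cytotoxicity, read by MTT assay, with a stated time of 72 h; on this read-out higher numbers stand for lower toxicity in this test and lower numbers for higher toxicity in this test:

- compound 1 `C=c1[nH]c(=O)/c(=C/c2ccsc2)[nH]c1=O`: > 20000 nM
- compound 2 `C=c1[nH]c(=O)/c(=C/c2ccc(C)cc2)[nH]c1=O`: > 20000 nM

Compound 2 gives > 20000 nM, and this is a limit of the assay, not a number. Compound 1 gives > 20000 nM, which is also a limit. The series therefore stands at the limit of > 20000 nM in this assay, at which 2 of the 2 values shown sit, and no numerical value is available for either compound.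

Compound 3 `C=c1[nH]c(=O)/c(=C/c2ccc(C(F)(F)F)cc2)[nH]c1=O` carries trifluoromethyl in place of methyl on an aromatic carbon of compound 2, para to a large group: trifluoromethyl in place of methyl on an aromatic carbon. The rest of the structure is unchanged.

Among the measured compounds shown here, no pair of measured compounds gives a numerical step in this assay, so the size of this change has no direct precedent. The expected change is none beyond the scatter, with no direction favoured. The estimated step is a number no higher from compound 2 to compound 3 (the limit leaves the size open). This expectation rests on compound 2, whose reading of > 20000 nM is a limit. A further limit rather than a number is the likeliest report.

For compound 3 the estimated value is 20000 nM, with an expected range of 10000 nM to 40000 nM.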

Compound 3, half-maximal cytotoxic concentration: > 20000 nM
Compound 3: no number, only a limit; the forecaster's own chance of this, stated with the estimate: 70%; the middle value lies on the limit itself.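

In this assay compound 3 gives > 20000 nM, which is a limit and not a number. Compound 2 also sits at a limit, and no step can be read between the two compounds. The series stands unchanged: the limit of > 20000 nM in this assay, at which 3 of the 3 values shown sit.

The compounds shown leave open what numerical value any of the three would give in this assay.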